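The source may hold more compounds than are shown below. What is called first, only, known or untested is meant among the compounds shown, and "the series" means these compounds.

Compound 1 `O=C(Nc1ccccc1)c1c(NO)cc(-c2ccccc2)oc1=O` gives 11600 nM in an ADME assay on Huh-7 cells (Homo sapiens) for cytotoxicity, read by a luciferase reporter and WST assay, with a stated time of 3 days; on this read-out lower numbers stand for higher toxicity in this test and higher numbers for lower toxicity in this test.
Compound 2 `O=C(Nc1ccccc1)c1c(NO)cc(-c2ccc(Cl)cc2)oc1=O` gives 11000 nM.
Compound 3 `Cc1ccc(-c2cc(NO)c(C(=O)Nc3ccccc3)c(=O)o2)cc1` reaches only a limit, > 20000 nM.

Of the two numbers, compound 1 stands highest, with compound 2 nearest: a 1.1-fold lower number from compound 1 to compound 2 (0.02 log units; within the scatter). Compound 3 sits at the limit of > 20000 nM in this assay, at which 1 of the 3 values shown sits; the steps to it read an at least 1.7-fold higher number from compound 1 to compound 3 (0.23 log units; that floor lies within the scatter) and an at least 1.8-fold higher number from compound 2 to compound 3 (0.25 log units; that floor lies within the scatter). Every measured change, then, sits on an aromatic carbon and stays within the scatter.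

Within the data shown here, compound 4 `CCNC(=O)c1c(NO)cc(-c2ccccc2)oc1=O` differs from compound 1 by ethyl in place of phenyl on an amide-type nitrogen, a change on the amide-type nitrogen that no measured step touches. With nothing shown moving this read-out beyond the scatter, no step beyond it is expected here either. Compound 4 is therefore estimated at 14000 nM, between 6000 nM and 30000 nM, an expected step of a 1.2-fold higher number from compound 1 to compound 4 (0.08 log units; within the scatter).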

Compound 4, half-maximal cytotoxic concentration: > 20000 nM
Compound 4: no number, only a limit; the forecaster's own chance of this, stated with the estimate: 35%; middle value at least 1.4-fold (0.15 log units) from the limit.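

The first change shown on the amide-type nitrogen, anilino to ethylamino, reads in this assay as an at least 1.7-fold higher number from compound 1 to compound 4 (0.23 log units; that floor lies within the scatter). Compound 4 reaches only a limit, the second compound here to do so: the limit of > 20000 nM in this assay, at which 2 of the 4 values shown sit. So this step gives only a floor, and replacing phenyl with ethyl at this position shows no sign of a lower number.

The compounds shown leave open whether a longer chain, or a chain carrying an amine or a carboxylic acid, on the amide-type nitrogen would move this read-out beyond the scatter. They also leave open whether chloro or methyl on the aromatic carbon reads the same with ethyl on that nitrogen.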